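Series notes: aryl exchange on the saturated ring carbon

The compounds below may be only part of what the source reports. "The series", "measured", "known", "first", "only" and "open" are said of these compounds alone.

Measured so far in a functional assay on HepG2 cells (Homo sapiens) for cytotoxicity, read by MTT assay, with a stated time of 72 h; a lower number here means a stronger inhibitor, a higher number a weaker inhibitor:
compound 1 `COc1ccc2ccc(=O)oc2c1C1=NN(C(N)=O)C(c2ccc(SC)cc2)C1` gives 18 nM
compound 2 `COc1ccc2ccc(=O)oc2c1C1=NN(C(N)=O)C(c2ccc(C)cc2)C1` gives 46 nM
compound 3 `COc1ccc2ccc(=O)oc2c1C1=NN(C(N)=O)C(c2cccs2)C1` gives 26 nM

Compound 3 has the second highest of the three numbers. Its neighbours are close: the step of a 1.4-fold higher number from compound 1 to compound 3 (0.16 log units; within the scatter) and the step of a 1.8-fold lower number from compound 2 to compound 3 (0.25 log units; within the scatter) both lie within the scatter, so no order among compounds 1, 2 and 3 is claimed in this assay. Among the measured compounds shown here, the one step beyond the scatter, a 2.6-fold higher number from compound 1 to compound 2 (0.41 log units; beyond the scatter), concerns a group on the aromatic ring rather than the exchange of the whole aromatic group.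

Compound 4 `COc1ccc2ccc(=O)oc2c1C1=NN(C(N)=O)C(c2ccccc2)C1` is the next member. It differs from compound 3 by phenyl in place of thiophen-2-yl on a saturated ring carbon.

For the measured compounds named here, the steps that bear on this change are the two aryl exchanges, compound 1 to compound 3 and compound 2 to compound 3, both within the scatter. Compound 4 carries a phenyl with no further group, and the two phenyl compounds that do carry one differ from each other by the modest step from compound 1 to compound 2. On that basis the step of a 1.9-fold higher number from compound 3 to compound 4 (0.28 log units; within the scatter) is expected to be small, most likely within the scatter or a little upward. Compound 4 is therefore estimated at 50 nM, with a range of 20 nM to 130 nM.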

Compound 4, half-maximal inhibitory concentration: 90 nM
Compound 4: the middle estimate sits 1.8-fold (0.26 log units) below what was measured, within the range that was stated.
By their numbers in this assay, from the lowest: compounds 1, 3, 2 and 4 (each within the scatter of the next, the first and the last beyond it).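

In this assay, exchanging the whole aromatic group on this saturated ring carbon now gives a step beyond the scatter (a 3.5-fold higher number from compound 3 to compound 4 (0.54 log units; beyond the scatter)), whereas the two earlier aryl exchanges stayed within it, so thiophen-2-yl and unsubstituted phenyl can be told apart here, if only modestly. The group on the phenyl also counts: hydrogen in place of methylsulfanyl gives a step beyond the scatter (a 5.0-fold higher number from compound 1 to compound 4 (0.70 log units; beyond the scatter)), while hydrogen in place of methyl stays within it (a 2.0-fold higher number from compound 2 to compound 4 (0.29 log units; within the scatter)), so no order is claimed between compound 2 and compound 4, and compound 1 stands apart from both. Nothing available bears on the reason for these steps.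

Whether the thiophen-2-yl result extends to other five-membered aromatic rings remains open, as furan-2-yl and thiazol-2-yl are not among the compounds shown. On the phenyl, the series shows only methyl and methylsulfanyl, leaving open how a methoxy, a chlorine, an amine or a longer thioether chain such as ethylsulfanyl would compare with compound 1 and compound 4.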